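Notes on the aryl step from compound 1 to compound 4

A few compounds are considered here, and "the series" means these few. Any claim that something is new, unique, unknown or untested is made for them only; others in the source may bear on it.

Measured so far:
- compound 1 `NC1=NC2(CCSCC2)N(OCCCOc2ccc(Cl)c(Cl)c2)C(N)=N1` gives 1 nM
- compound 2 `COc1ccc(OCCCON2C(N)=NC(N)=NC23CCOCC3)cc1` gives 660 nM
- compound 3 `NC1=NC2(CCOCC2)N(OCCCOc2ccc(Cl)c(Cl)c2)C(N)=N1` gives 790 nM

In a functional assay on A549 cells (Homo sapiens) for antiproliferative activity, read by MTT assay, with a stated time of 72 h (on this read-out higher numbers stand for weaker inhibition and lower numbers for stronger inhibition), compound 1 holds the lowest of the three numbers, well beyond the scatter from both of the others. The next compound to be measured is compound 4 `NC1=NC2(CCSCC2)N(OCCCOc2ccccc2Cl)C(N)=N1`, which keeps the core of compound 1. The change is 2-chlorophenyl in place of 3,4-dichlorophenyl on an oxygen on a saturated carbon and amounts to 2-chlorophenyl in place of 3,4-dichlorophenyl on an oxygen on a saturated carbon.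

For the measured compounds named here, only one measured step touches this aryl group: a 1.2-fold higher number from compound 2 to compound 3 (0.08 log units; within the scatter) for 3,4-dichlorophenyl in place of 4-methoxyphenyl. Going by the values given here, that step suggests little sensitivity to the aryl group, but it was measured on the core of compound 2 and not on that of compound 1, and 2-chlorophenyl itself has no measured precedent. Among the compounds with values here, no large step is therefore expected. Compound 1 at 1 nM sits at the low extreme of the set, so a modest rise is more likely than a further fall. The expected change is a 6.0-fold higher number from compound 1 to compound 4 (0.78 log units; beyond the scatter) in this assay and remains uncertain. Compound 4 is estimated at 6 nM with an expected range from 1 nM to 100 nM as its limits of estimation.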

Compound 4, half-maximal inhibitory concentration: 80 nM
For compound 4 the middle estimate is 13-fold (1.12 log units) below the measured one; low and high end bracket the measured number.
By their numbers in this assay, from the lowest: compound 1; then compound 4; then compounds 2 and 3 (each within the scatter of the next).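

In this assay, the aryl group on the oxygen on a saturated carbon is a sensitive place on the core of compound 1, with an 80-fold higher number from compound 1 to compound 4 (1.90 log units; beyond the scatter) for 2-chlorophenyl in place of 3,4-dichlorophenyl. For the compounds shown here, the only earlier aryl step, a 1.2-fold higher number from compound 2 to compound 3 (0.08 log units; within the scatter), lay within the scatter, but it stands on a different core and exchanges a different pair of groups, so the two steps together show that this place can carry a large step, not that the core sets its size. No measured evidence is available to account for the new step.

Still open, on these data alone, is whether the step follows from the number of chlorine atoms on the ring or from their placement, which a plain phenyl on the core of compound 1 would begin to separate. Also open, as far as these compounds go, is how 4-methoxyphenyl would read on that core, which would allow a direct comparison with the step on the other core, and how a ring carrying a carboxylic acid or an amine would read at this place.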